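This account rests on a few compounds, and the source may have more. Where it says the series, first, only, none or still open, it means among the compounds named here.

Measured so far:
compound 1 `CCN1CC(NC(=O)[C@@H]2CCCN(S(=O)(=O)c3ccc(S(=O)(=O)N(CC)CC)cc3)C2)C1` — > 30000 nM
compound 2 `CCN(CC)S(=O)(=O)c1ccc(S(=O)(=O)N2CCC[C@@H](C(=O)N[C@H]3CCN(C(=O)OC(C)(C)C)C3)C2)cc1` — 300 nM

In a functional assay on BXPC-3 cells (Homo sapiens) for inhibition, read by MTT assay, with a stated time of 7 days (on this read-out higher numbers stand for weaker inhibition and lower numbers for stronger inhibition), compound 1 gives only a limit, > 30000 nM, with no number behind it; this is the limit of > 30000 nM in this assay, at which 1 of the 2 values shown sits. Going by the values given here, compound 2 gives 300 nM; the one measured step, an at least 100-fold lower number from compound 1 to compound 2 (2.00 log units; beyond the scatter), swaps only the amide substituent. Compound 3 `CCN(CC)S(=O)(=O)c1ccc(S(=O)(=O)N2CCC[C@@H](c3cc(C)no3)C2)cc1` goes further: 3-methyl-1,2-oxazol-5-yl in place of (1-ethylazetidin-3-yl)carbamoyl on a saturated ring carbon. Among the compounds with values here, no measured step removes the carboxamide, so the step from compound 2 gives only a loose pointer. For compound 3 a move off the limit is expected, an at least 10-fold lower number from compound 1 to compound 3 (1.00 log units; beyond the scatter), giving 3000 nM with a range of 300 nM to 30000 nM.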

Compound 3, half-maximal inhibitory concentration: 7700 nM
Compound 3: middle estimate off by 2.6-fold (0.41 log units), on the low side; the range from low to high includes it.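

Carbonyl and amide hydrogen are not needed at this saturated ring carbon for a measurable number: in this assay, 3-methyl-1,2-oxazol-5-yl in place of (1-ethylazetidin-3-yl)carbamoyl gives an at least 3.8-fold lower number from compound 1 to compound 3 (0.59 log units; beyond the scatter). The number of compound 3, 7700 nM, stays higher than that of compound 2, 300 nM. Compound 1 is a limit, so this step gives only a minimum size: the limit of > 30000 nM in this assay, at which 1 of the 3 values shown sits.

Open, from the compounds shown here alone, is how a primary amine or a carboxylic acid at this ring carbon would read. Also open, going by these compounds, is whether the oxazole without its methyl group would hold the number of compound 3.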